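The source may hold more compounds than are shown below. What is called first, only, known or untested is meant among the compounds shown, and "the series" means these compounds.

Measured so far in this series:
compound 2, `COc1cc2c(Nc3ccc(Br)cc3Cl)ncnc2c(OC)c1OC` — 21000 nM
compound 1, `COc1cc2c(Nc3cccc([N+](=O)[O-])c3)ncnc2c(OC)c1OC` — 24400 nM

Both measured compounds share one core and differ only in the aryl group on the ring nitrogen. In a functional assay on PC-3 cells (Homo sapiens) for inhibition, read by MTT assay, with a stated time of 72 h (a lower number here means a stronger inhibitor, a higher number a weaker inhibitor), compound 2 gives 21000 nM, the lowest of the two numbers shown. Compound 1 gives 24400 nM in this assay, which lies within the scatter of compound 2, so the two cannot be placed in order; both are weak inhibitors.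

Compound 3, `COc1cc2c(Nc3ccc(Cl)cc3)ncnc2c(OC)c1OC`, is not yet measured. It differs from compound 2 by 4-chlorophenyl in place of 4-bromo-2-chlorophenyl on a nitrogen on an aromatic ring. For the measured compounds named here, no measured pair shows this change, so the expectation rests on the two weak values alone. A step within the scatter, in no clear direction, is the working assumption. The step from compound 2 to compound 3 is expected to be a 1.1-fold lower number from compound 2 to compound 3 (0.02 log units; within the scatter). Compound 3 is therefore estimated at 20000 nM, with a range from 7000 nM to 60000 nM.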

Compound 3, half-maximal inhibitory concentration: 31000 nM
Estimate against measurement, compound 3: 1.6-fold (0.19 log units) below, and the stated range covers the measured number.
By their numbers in this assay, from the lowest: compounds 2, 1 and 3 (each within the scatter of the next).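

In this assay, for the compounds shown here, this is the first single-place pair, and it gives a 1.5-fold higher number from compound 2 to compound 3 (0.17 log units; within the scatter). On a nitrogen on an aromatic ring, 4-chlorophenyl in place of 4-bromo-2-chlorophenyl therefore gives no readable difference, and this one pair shows that the exchange leaves the number in the same weak range. No available evidence bears on this result.

From the compounds shown here alone, it remains open whether an aryl group carrying an amine or a carboxylic acid, or a longer chain in place of the aryl group, would give a number beyond the scatter in this assay. Also open is whether any change to the shared core would separate compounds that the aryl exchange shown here does not.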